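Fluoro and methoxy exchange from compound 3 to compound 4

The compounds below may be only part of what the source reports. "The series", "measured", "known", "first", "only" and "open" are said of these compounds alone.

Measured in a functional assay on THP-1 cells (Homo sapiens); on this read-out higher numbers stand for weaker inhibition and lower numbers for stronger inhibition:
Compound 1 `CCSC[C@@](O)([C@@H](Nc1cccc2nc(C)ccc12)c1ccc(OC)cc1)C(F)(F)F` gives 6.31 nM
Compound 2 `CCSC[C@@](O)([C@@H](Nc1cccc2nc(C)ccc12)c1cccc(F)c1OC)C(F)(F)F` gives 2 nM
Compound 3 `CCSC[C@@](O)([C@@H](Nc1cccc2nc(C)ccc12)c1ccc(F)cc1OC)C(F)(F)F` gives 5.01 nM

Compound 3, at 5.01 nM, is second highest of the three numbers. It lies within the scatter of compound 1 and clearly above compound 2, as shown by a 2.5-fold higher number from compound 2 to compound 3 (0.40 log units; beyond the scatter).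

Compound 4 `CCSC[C@@](O)([C@@H](Nc1cccc2nc(C)ccc12)c1ccc(OC)cc1F)C(F)(F)F` is the next structure, with this change: 2-fluoro-4-methoxyphenyl in place of 4-fluoro-2-methoxyphenyl on a saturated chain carbon bound to a nitrogen on an aromatic ring and a saturated chain carbon. Within the data shown here, no measured step makes this exact exchange, so the evidence is indirect. Among the methoxyphenyl variants, a 1.3-fold lower number from compound 1 to compound 3 (0.10 log units; within the scatter), while a 3.2-fold lower number from compound 1 to compound 2 (0.50 log units; beyond the scatter). Moving the fluoro group alone gave the modest step already noted, so the arrangement on this ring can matter. Still, all three values lie close together, and the new group contains the 4-methoxyphenyl of compound 1.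

The step expected in this assay is a 1.3-fold lower number from compound 3 to compound 4 (0.10 log units; within the scatter), with no change beyond the scatter expected. Compound 4 is estimated at 4 nM, with an expected range from 1.6 nM to 10 nM.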

Compound 4, half-maximal inhibitory concentration: 5.01 nM
Compound 4: the middle estimate sits 1.3-fold (0.10 log units) below what was measured; the range from low to high includes it.
By their numbers in this assay, from the lowest: compound 2; then compounds 3, 4 and 1 (each within the scatter of the next).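

In this assay, exchanging the fluoro and methoxy places on this ring gives no change at the digits printed from compound 3 to compound 4 (within the scatter), and fluoro on the 4-methoxyphenyl ring gives a 1.3-fold lower number from compound 1 to compound 4 (0.10 log units; within the scatter). Among these compounds, the 3-fluoro-2-methoxyphenyl group alone stands apart, with a 2.5-fold higher number from compound 2 to compound 4 (0.40 log units; beyond the scatter), and it is the only one of the four rings whose steps to all the others lie beyond the scatter. The 4-methoxyphenyl, 4-fluoro-2-methoxyphenyl and 2-fluoro-4-methoxyphenyl groups therefore cannot be told apart on this read-out, so at this position only one of the three fluoro arrangements shown separates from the rest.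

Nothing available here accounts for the separate standing of that one arrangement. From the compounds shown here alone, whether a chloro group, a nitrile or an amine in place of its fluoro would stay close to compound 2 at 2 nM remains open.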